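Cyano-substituted benzyl ether: expected intrinsic activity

This account rests on a few compounds, and the source may have more. Where it says the series, first, only, none or still open, it means among the compounds named here.

Measured so far:
compound 1 `C[C@@H]1CN(c2ncc(OCc3ccc(S(C)(=O)=O)cc3)cn2)[C@@H](C)CN1C(=O)OC(C)(C)C` — 3%
compound 2 `C[C@@H]1CN(C(=O)OC(C)(C)C)CCN1c1ncc(OCC2CCN(S(C)(=O)=O)CC2)cn1` — 67%

In a functional assay on isolated protein with Glucose-dependent insulinotropic receptor (Mus musculus) as the target, read by HTRF and cAMP accumulation, with a stated time of 45 min (on this read-out lower numbers stand for smaller maximal responses and higher numbers for larger maximal responses), compound 2 gives 67%, the higher of the two numbers; compound 1 gives 3%, a gap beyond the scatter, though the two also differ in the shared core. Compound 3 `C[C@@H]1CN(C(=O)OC(C)(C)C)CCN1c1ncc(OCc2ccc(C#N)cc2)cn1` has not been measured. It differs from compound 2 by 4-cyanophenyl in place of 1-(methylsulfonyl)piperidin-4-yl on a saturated chain carbon bound to an oxygen on an aromatic ring. Going by the values given here, no measured step isolates this change. Given the low number of compound 1 with its 3%, a downward step beyond the scatter is expected, a number 32 percentage points lower from compound 2 to compound 3 (beyond the scatter). Compound 3 is estimated at 35%, range 5% to 70%.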

Compound 3, intrinsic activity: the largest response reached, in percent of the reference agonist's: 88%
Compound 3: middle estimate off by 53 percentage points, on the low side; the whole stated range lies below it.
By their numbers in this assay, from the lowest: compound 1; then compound 2; then compound 3.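

In this assay, 4-cyanophenyl in place of 1-(methylsulfonyl)piperidin-4-yl on a saturated chain carbon bound to an oxygen on an aromatic ring gives a number 21 percentage points higher from compound 2 to compound 3 (beyond the scatter) on the shared core. This place therefore accepts a six-membered aromatic ring of carbon only with a large maximal response, so such a ring here does not by itself give a low number. No measurement bears on the reason for this step.

Compound 1 differs from compound 3 in more than one place, so its low number cannot be assigned to either change. Going by these compounds, whether a carboxylic acid or an amine in place of the nitrile keeps the response remains open.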